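Changing the amide group of compound 3

The compounds below may be only part of what the source reports. "The series", "measured", "known", "first", "only" and "open" are said of these compounds alone.

Measured so far in a physicochemical assay for solubility, read by HPLC, in phosphate buffer, measured as kinetic solubility, at pH 7.4; a higher number here means a more soluble compound, a lower number a less soluble compound:
- compound 1 `NS(=O)(=O)c1ccc(-c2cc(C(=O)C3CCC3)nn2-c2ccc(Cl)cc2)cc1` gives 17200 nM
- compound 2 `NS(=O)(=O)c1ccc(-c2cc(C(=O)CC3CCCC3)nn2-c2ccc(Cl)cc2)cc1` gives 2600 nM
- compound 3 `NS(=O)(=O)c1ccc(-c2cc(C(=O)N3CCCC3)nn2-c2ccc(Cl)cc2)cc1` gives 57900 nM

Compound 3 holds the highest of these three numbers. Compound 4 `CN(C(=O)c1cc(-c2ccc(S(N)(=O)=O)cc2)n(-c2ccc(Cl)cc2)n1)C1CC(F)(F)C1` differs from it as follows: (3,3-difluorocyclobutyl)(methyl)amino in place of pyrrolidin-1-yl on a carbonyl carbon, on a carbonyl carbon. Among the measured compounds shown here, no measured step makes this exact swap. The nearest guide is a 6.6-fold lower number from compound 1 to compound 2 (0.82 log units; beyond the scatter), with the larger cyclopentylmethyl in place of cyclobutyl. Against any simple size rule stands a 3.4-fold higher number from compound 1 to compound 3 (0.53 log units; beyond the scatter), and a 22-fold higher number from compound 2 to compound 3 (1.35 log units; beyond the scatter) is large, but both of these steps bring in the pyrrolidin-1-yl group rather than change it. A modest fall in this assay is therefore expected, estimated as a 2.9-fold lower number from compound 3 to compound 4 (0.46 log units; beyond the scatter) overall. Compound 4 is expected near 20000 nM, with an estimated range from 6000 nM to 60000 nM in this measurement.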

Compound 4, solubility: 30900 nM
The estimate for compound 4 lay 1.5-fold (0.19 log units) below the measured number, and the stated range covers the measured number.
By their numbers in this assay, from the lowest: compound 2; then compounds 1, 4 and 3 (each within the scatter of the next, the first and the last beyond it).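

In this assay, the larger (3,3-difluorocyclobutyl)(methyl)amino group on the carbonyl carbon reads much like pyrrolidin-1-yl (a 1.9-fold lower number from compound 3 to compound 4 (0.27 log units; within the scatter)), so adding heavy atoms here need not shift the number beyond the scatter. The same group stands far from cyclopentylmethyl (a 12-fold higher number from compound 2 to compound 4 (1.07 log units; beyond the scatter)) but not from cyclobutyl (a 1.8-fold higher number from compound 1 to compound 4 (0.25 log units; within the scatter)), so size alone does not order these four compounds. Nothing available explains these differences. Still open, on these data alone, is whether the two fluorine atoms of compound 4 matter, and how a morpholin-4-yl group would compare at this carbonyl carbon.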